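Swapping methoxy for chloro on compound 2

The source may report more compounds than this note shows. Statements on the series, on what has been measured and on what is new or still open speak of the compounds shown alone.

Compound 2 `COc1ccc(C2=Nn3c(nnc3C(C)c3ccc(-c4ccccc4)c(F)c3)SC2)cc1` is one of three compounds tested in a functional assay on SNU-475 cells (Homo sapiens) for inhibition, read by sulforhodamine B assay, with a stated time of 72 h; a higher number here means a weaker inhibitor, a lower number a stronger inhibitor. In this assay compound 2 gives 6700 nM, the second highest of the three numbers. Compound 1 `CC(c1ccc(-c2ccccc2)c(F)c1)c1nnc2n1N=C(c1ccc(Cl)cc1Cl)CS2` gives 4700 nM, and the step of a 1.4-fold higher number from compound 1 to compound 2 (0.15 log units; within the scatter) stays within the scatter. Compound 3 `COc1ccc2cc(C(C)c3n[nH]c(=S)n3N)ccc2c1`, which differs from both in several places, gives 15900 nM, a number beyond the scatter from that of compound 2.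

Compound 4 `CC(c1ccc(-c2ccccc2)c(F)c1)c1nnc2n1N=C(c1ccc(Cl)cc1)CS2` differs from compound 2 in a single place: chloro in place of methoxy on an aromatic carbon. Going by the values given here, the only measured step that bears on this change is a 1.4-fold higher number from compound 1 to compound 2 (0.15 log units; within the scatter), where a ring carrying two chloro groups was exchanged for the methoxy-bearing ring without moving the number beyond the scatter. A single chloro in the same position is therefore expected to leave the number where it is, and the estimated step of a 1.2-fold lower number from compound 2 to compound 4 (0.09 log units; within the scatter) lies within the scatter. In this assay compound 4 is expected to give about 5500 nM, within a range from 2500 nM to 12000 nM.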

Compound 4, half-maximal inhibitory concentration: 3800 nM
The estimate for compound 4 lay 1.4-fold (0.16 log units) above the measured number; the measured number falls inside the stated range.
By their numbers in this assay, from the lowest: compounds 4, 1 and 2 (each within the scatter of the next); then compound 3.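

Chloro in place of methoxy on the ring gives a 1.8-fold lower number from compound 2 to compound 4 (0.25 log units; within the scatter), and hydrogen in place of one chloro on the ring of compound 1 gives a 1.2-fold lower number from compound 1 to compound 4 (0.09 log units; within the scatter). Neither step leaves the scatter of this assay, so 4-methoxyphenyl, 4-chlorophenyl and the ring with two chloro groups cannot be told apart here, and this now rests on single-group exchanges rather than only on the earlier exchange that altered the ring in more than one place. No measured property of these groups is available to account for this result.

Still open, on these data alone, is whether any group at this position can move the number beyond the scatter, as an amine, a carboxylic acid or a longer chain in place of the chloro might. Also open, as far as these compounds go, is where a plain phenyl ring, with hydrogen in that place, would fall.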